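Exchanging the aryl ether group on a shared diamide core

This account rests on a few compounds, and the source may have more. Where it says the series, first, only, none or still open, it means among the compounds named here.

Compound 1, `CN(C)c1ccc(C(=O)Nc2cccc(NC(=O)COc3ccc4c(c3)NC(=O)CC4)c2)cc1`, sits at the assay limit > 10000 nM in an assay on isolated protein for inhibition of Rho-associated protein kinase 1 (Homo sapiens), read by scintillation counting, radiometric assay and 33P incorporation, with a stated time of 40 min, in the presence of a further agent that is not named here (a higher number here means a weaker inhibitor, a lower number a stronger inhibitor), which is a limit and not a number. Compound 2, `COc1ccc(OCC(=O)Nc2cccc(NC(=O)c3ccc(N(C)C)cc3)c2)cc1F`, gives 1820 nM in this assay. Compound 3, `CC(=O)c1ccc(OCC(=O)Nc2cccc(NC(=O)c3ccc(N(C)C)cc3)c2)cc1F`, gives 445 nM in this assay.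

Compound 3 stands lowest of the two numbers shown; its nearest neighbour is compound 2, and the step of a 4.1-fold lower number from compound 2 to compound 3 (0.61 log units; beyond the scatter) lies beyond the scatter. Compound 1 is known only through (the limit of > 10000 nM in this assay, at which 1 of the 3 values shown sits).

Compound 4, `CN(C)c1ccc(C(=O)Nc2cccc(NC(=O)COc3ccc4occc(=O)c4c3)c2)cc1`, differs from compound 3 by a group of 11 heavy atoms (9 carbon, 2 oxygen; one six-membered aromatic ring of carbon only, one six-membered aromatic ring with 1 hetero atom) in place of a group of 10 heavy atoms (8 carbon, 1 oxygen, 1 fluorine; one six-membered aromatic ring of carbon only), on an oxygen on a saturated carbon. Among the compounds with values here, the steps that bear on this are an at least 22-fold lower number from compound 1 to compound 3 (1.35 log units; beyond the scatter) and an at least 5.4-fold lower number from compound 1 to compound 2 (0.73 log units; beyond the scatter), in which a fused two-ring group on the ether oxygen gave the highest number of the set and a single aromatic ring gave a number beneath it. Compound 4 brings back a fused two-ring group, so a higher number is expected: a 5.6-fold higher number from compound 3 to compound 4 (0.75 log units; beyond the scatter). Compound 4 is therefore estimated at 2500 nM, within a range from 600 nM to 10000 nM.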

Compound 4, half-maximal inhibitory concentration: > 10000 nM
Compound 4 was reported as a limit; the forecaster's own chance of this, stated with the estimate: 25%; at least 4.0-fold (0.60 log units) between middle value and limit.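

In this assay this change gives an at least 22-fold higher number from compound 3 to compound 4 (1.35 log units; beyond the scatter) and the matching change from the methoxy-bearing ring gives an at least 5.4-fold higher number from compound 2 to compound 4 (0.73 log units; beyond the scatter) on the same oxygen on a saturated carbon. The result for compound 4 is a limit, not a number. Both fused two-ring groups shown now stand at the limit while both single-ring groups give numbers, and no compound shown goes against this: the limit of > 10000 nM in this assay, at which 2 of the 4 values shown sit.

The step between compound 1 and compound 4 cannot be read. Going by these compounds, whether a single ring carrying an amine or a carboxylic acid in place of acetyl would keep a number in this assay stays open, as does whether any fused two-ring group can give one.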